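The source may report more compounds than this note shows. Statements on the series, on what has been measured and on what is new or still open speak of the compounds shown alone.

In an ADME assay on HepG2 2.2.15 cells (Homo sapiens) for cytotoxicity (a higher number here means that more compound is tolerated, a lower number that less compound is tolerated), the measured compounds are these:

- compound 1 (`O=CCc1c(-c2ccccc2Cl)c2cc(Cl)ccc2[nH]c1=O`) gives 120000 nM
- compound 2 (`CCCCCCCC(=O)OCCc1c(-c2ccccc2Cl)c2cc(Cl)ccc2[nH]c1=O`) gives 78000 nM
- compound 3 (`O=C(O)CCCC(=O)OCCc1c(-c2ccccc2Cl)c2cc(Cl)ccc2[nH]c1=O`) gives 110000 nM

Compound 3 stands level with both of the others, since a 1.1-fold lower number from compound 1 to compound 3 (0.04 log units; within the scatter) and a 1.4-fold higher number from compound 2 to compound 3 (0.15 log units; within the scatter) each lie within the scatter, and no order among the three can be read. Compound 4 (`CCOCC(=O)OCCc1c(-c2ccccc2Cl)c2cc(Cl)ccc2[nH]c1=O`) carries ethoxy in place of 2-carboxyethyl on a saturated chain carbon bound to a carbonyl carbon. Going by the values given here, no measured compound carries ethoxy, so the evidence is indirect. The closest guide is a 1.4-fold higher number from compound 2 to compound 3 (0.15 log units; within the scatter) and it also takes carboxy away from or onto the chain, while a 1.1-fold lower number from compound 1 to compound 3 (0.04 log units; within the scatter) is a larger structural change that likewise leaves the number within the scatter. On these two steps, the estimated 1.1-fold lower number from compound 3 to compound 4 (0.04 log units; within the scatter) is expected to stay within the scatter in this assay with no firm direction. For compound 4 the estimated value is 100000 nM with an expected range of 60000 nM to 160000 nM at most.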

Compound 4, half-maximal cytotoxic concentration: 130000 nM
Estimate against measurement, compound 4: 1.3-fold (0.11 log units) below, and the stated range covers the measured number.
By their numbers in this assay, from the lowest: compounds 2, 3, 1 and 4 (each within the scatter of the next).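

In this assay, ethoxy in place of 2-carboxyethyl on a saturated chain carbon bound to a carbonyl carbon gives a 1.2-fold higher number from compound 3 to compound 4 (0.07 log units; within the scatter) and thereby shows that this place accepts a group without the carboxy hydrogen-bond donor while the number stays within the scatter. Ethoxy in place of hexyl at the same place gives a 1.7-fold higher number from compound 2 to compound 4 (0.22 log units; within the scatter) and the wider change from the formyl compound gives a 1.1-fold higher number from compound 1 to compound 4 (0.03 log units; within the scatter) so none of the three steps to compound 4 leaves the scatter, and ethoxy adds a third kind of group at this place to the two already seen. Nothing measured here accounts for this lack of movement.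

From the compounds shown here alone, whether an amine or a phenyl ring at this place would carry the number beyond the scatter remains open. The compounds shown also share one core, so they leave open how the number responds to replacing either chlorine with fluorine or a methyl group.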